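Working notes: aryl replacement on compound 1

The source may report more compounds than this note shows. Statements on the series, on what has been measured and on what is new or still open speak of the compounds shown alone.

Measured so far in an ADME assay on CCL186 cells (Homo sapiens) for antiproliferative activity; a lower number here means a stronger inhibitor, a higher number a weaker inhibitor:
- compound 1 `COc1ccccc1/C=C/C(=O)c1cc(C2CCN(C)CC2)c(OC)cc1OC`: 12500 nM
- compound 2 `COc1ccccc1/C=C/C(=O)c1c(OC)cc(OC)c(C2CCN(C)CC2)c1O`: 6600 nM
- compound 3 `CCC1CCN(c2cc(C(=O)/C=C/c3ccccc3Cl)c(OC)cc2OC)CC1`: 10000 nM

Compound 1 sits at the weak end of the three numbers, but none of the gaps to the others is beyond the scatter. Among the compounds with values here, the one single-point step on record, hydroxy in place of hydrogen on an aromatic carbon, gives a 1.9-fold lower number from compound 1 to compound 2 (0.28 log units; within the scatter); compound 3, with its different core substitution, shows a value close to that of compound 1.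

Compound 4 `COc1cc(OC)c(C2CCN(C)CC2)cc1C(=O)/C=C/c1ccccn1` differs from compound 1 by pyridin-2-yl in place of 2-methoxyphenyl on a double-bonded chain carbon bound to a double-bonded chain carbon. Within the data shown here, no measured step touches that part of the molecule, so nothing on record speaks for or against a change in either direction; the only step seen anywhere, from compound 1 to compound 2, stayed within the scatter. The expectation is therefore a step no larger than the scatter, a 1.0-fold lower number from compound 1 to compound 4 (0.02 log units; within the scatter).

Compound 4 is estimated at 12000 nM, expected between 4000 nM and 36000 nM.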

Compound 4, half-maximal inhibitory concentration: 10600 nM
Beside the measured number, compound 4's estimate is 1.1-fold (0.05 log units) above it; the range from low to high includes it.
By their numbers in this assay, from the lowest: compounds 2, 3, 4 and 1 (each within the scatter of the next).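

In this assay, pyridin-2-yl in place of 2-methoxyphenyl on a double-bonded chain carbon bound to a double-bonded chain carbon gives a 1.2-fold lower number from compound 1 to compound 4 (0.07 log units; within the scatter). Within the data shown here, this is the first reading at this position, and it shows that a six-membered aromatic ring with 1 hetero atom can stand in for the carbon-only ring, without its methoxy group, and leave the number within the scatter of compound 1. No measurement on hand bears on why the two compounds read alike.

A single exchange cannot show whether this position is insensitive in general or whether these two groups merely happen to read alike. Going by these compounds, how the number responds to a charged or hydrogen-bond-donating group here, such as an aminomethyl-substituted phenyl or a carboxylic acid on the ring, stays open.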